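The source may hold more compounds than are shown below. What is called first, only, known or untested is meant among the compounds shown, and "the series" means these compounds.

Working notes on the series. One core is carried unchanged through compounds 1, 2 and 3; what varies is the group on a saturated chain carbon bound to an amine nitrogen in a ring. Compound 1 `Clc1cc(Cl)cc(CO[C@H]2CCCN(Cc3ccccc3)[C@H]2c2ccccc2)c1` bears phenyl there. In an assay on isolated protein for activation of cGMP-dependent protein kinase 1 (Homo sapiens), read by ADP-Glo, with stated times of 120 min and 40 min (on this read-out lower numbers stand for an effect already at smaller amounts and higher numbers for an effect only at larger amounts of compound), compound 1 gives > 200000 nM, which is a limit of the assay and not a number. Compound 2 `Clc1cc(Cl)cc(CO[C@H]2CCCN(Cc3nccs3)[C@H]2c2ccccc2)c1` carries 1,3-thiazol-2-yl in that place. In this assay compound 2 gives > 200000 nM, again a limit. Compound 3 `Clc1cc(Cl)cc(CO[C@H]2CCCN(Cc3ccncc3)[C@H]2c2ccccc2)c1` carries pyridin-4-yl. In this assay compound 3 gives > 200000 nM, also a limit. The steps a step that the two limits leave unreadable from compound 1 to compound 2, a step that the two limits leave unreadable from compound 1 to compound 3 and a step that the two limits leave unreadable from compound 2 to compound 3 are unreadable in size, all values sitting at the limit of > 200000 nM in this assay, at which 3 of the 3 values shown sit. Compound 3 thus stands at the limit together with the other two, with no number to set against them.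

Compound 4 `O=C(O)c1ccc(CN2CCC[C@H](OCc3cc(Cl)cc(Cl)c3)[C@@H]2c2ccccc2)cc1` differs from compound 3 by 4-carboxyphenyl in place of pyridin-4-yl on a saturated chain carbon bound to an amine nitrogen in a ring. Within the data shown here, none of the measured steps gives a readable size, so no direction can be drawn from them; the three limits only show that none of the groups tried so far brought the value into the measured range. The expectation for compound 4 is therefore a step that the limit leaves unreadable from compound 3 to compound 4 that stays at the limit. Compound 4 is estimated at 300000 nM, with a range from 100000 nM to 2000000 nM.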

Compound 4, half-maximal effective concentration: 76000 nM
Compound 4: middle estimate off by 3.9-fold (0.60 log units), on the high side, outside the stated range (below it).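

In this assay, 4-carboxyphenyl is the only one of the four groups shown on a saturated chain carbon bound to an amine nitrogen in a ring that gives a number and not a limit, with an at least 2.6-fold lower number from compound 3 to compound 4 (0.42 log units; beyond the scatter). The comparison with 1,3-thiazol-2-yl gives an at least 2.6-fold lower number from compound 2 to compound 4 (0.42 log units; beyond the scatter), and where carboxy in place of hydrogen on an aromatic carbon is the whole change, the comparison gives an at least 2.6-fold lower number from compound 1 to compound 4 (0.42 log units; beyond the scatter), so this place does respond to the group it carries. Each of these steps is a bound and not a size, and the steps among compound 1, compound 2 and compound 3 cannot be read, because they rest on a limit: the limit of > 200000 nM in this assay, at which 3 of the 4 values shown sit.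

Compound 4 is the only compound shown with a carboxy group, so this single result gives no trend, and how far the number can fall at this place remains unknown. Going by these compounds, it also remains open whether a methyl ester or a primary amide in place of the carboxy group would keep a measurable value, and whether a carboxylic acid on a longer chain would lower the number further.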